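From compound 2 to compound 3: expecting a large drop

A few compounds are considered here, and "the series" means these few. Any claim that something is new, unique, unknown or untested is made for them only; others in the source may bear on it.

In a physicochemical assay for solubility, at pH 7.4 (on this read-out higher numbers stand for higher solubility and lower numbers for lower solubility), compound 1 `CCOCc1nc(Nc2ccc(C(F)(F)F)cc2)c2ccc(-c3ncccc3C(F)(F)F)cc2n1` gives 0.6 ug/mL. Compound 2 `O=P(O)(O)OCc1nc(Nc2ccc(C(F)(F)F)cc2)c2ccc(-c3ncccc3C(F)(F)F)cc2n1` gives > 138 ug/mL, which is a limit of the assay and not an exact number. Compound 2 therefore stands at the limit of > 138 ug/mL in this assay, at which 1 of the 2 values shown sits.

Going by the values given here, only one measured step bears on what comes next: an at least 230-fold higher number from compound 1 to compound 2 (2.36 log units; beyond the scatter). That step is large and well beyond the scatter, and it brought in a group containing phosphorus. Compound 3 `OCCc1nc(Nc2ccc(C(F)(F)F)cc2)c2ccc(-c3ncccc3C(F)(F)F)cc2n1` has no phosphorus, and its difference from compound 2 is a group of 2 heavy atoms (1 carbon, 1 oxygen; no ring) in place of a group of 5 heavy atoms (4 oxygen, 1 phosphorus; no ring), on a saturated chain carbon bound to an aromatic carbon. In other words, hydroxymethyl now sits on a saturated chain carbon bound to an aromatic carbon.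

Compound 1 also lacks phosphorus and reads 0.6 ug/mL, so a large step down in this assay is expected, undoing most of the earlier rise. Hydroxymethyl has not been measured in this series, so the range must stay wide, mostly on the upper side. The estimated step is an at least 69-fold lower number from compound 2 to compound 3 (1.83 log units; beyond the scatter). Compound 3 is expected to read 2 ug/mL, with an estimated range of 0.5 ug/mL to 10 ug/mL.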

Compound 3, solubility: 0.02 ug/mL
Beside the measured number, compound 3's estimate is 100-fold (2.00 log units) above it, and the stated range ends above it.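

In this assay, hydroxymethyl in place of ethoxy on a saturated chain carbon bound to an aromatic carbon gives a 30-fold lower number from compound 1 to compound 3 (1.48 log units; beyond the scatter), so this position responds strongly even to a change that involves no phosphorus at all, which the earlier pair could not show. The distance from the phosphorus-containing group is also wider than the first step revealed, with an at least 6900-fold lower number from compound 2 to compound 3 (3.83 log units; beyond the scatter), and compound 1 turns out not to mark the floor for compounds without phosphorus. The size of that second step is only a lower bound, and its true size stays unknown because compound 2 reads at a limit of the assay and not at an exact number: the limit of > 138 ug/mL in this assay, at which 1 of the 3 values shown sits.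

As far as these compounds go, whether an amine, a carboxylic acid or a longer chain ending in a hydroxyl group at this place would read nearer compound 2 or nearer compound 3 remains open. The numbers also give the size of the step from ethoxy to hydroxymethyl but no reason for it, so what lies behind the lower reading of compound 3 is still unexplained.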